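From methylamino to dimethylamino on a shared core

This account rests on a few compounds, and the source may have more. Where it says the series, first, only, none or still open, it means among the compounds named here.

Compound 1 `Cc1cccc2c1nc(-c1c(F)cccc1F)n2Cc1c(F)cccc1F` gives > 100 uM (a limit)
Compound 2 `Oc1cccc2c1nc(-c1c(F)cccc1F)n2Cc1c(F)cccc1F` gives > 100 uM (a limit)
Compound 3 `CNc1cccc2c1nc(-c1c(F)cccc1F)n2Cc1c(F)cccc1F` gives 27.2 uM (a number)

Among the compounds with values here, all three compounds were tested in a toxicity assay on CCRF-CEM cells (Homo sapiens) for cytotoxicity (a higher number here means that more compound is tolerated, a lower number that less compound is tolerated), and differ in only one group on the shared core. Within the data shown here, compound 3 is the only one with an actual number, as the other two are reported only as limits of the assay.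

Compound 4 `CN(C)c1cccc2c1nc(-c1c(F)cccc1F)n2Cc1c(F)cccc1F` differs from compound 3 by one change, methyl in place of hydrogen on a nitrogen on an aromatic ring, which turns methylamino into dimethylamino. Among the measured compounds shown here, no measured step shows this change directly. The nearest evidence is an at least 3.6-fold lower number from compound 1 to compound 3 (0.56 log units; beyond the scatter) and an at least 3.6-fold lower number from compound 2 to compound 3 (0.56 log units; beyond the scatter), both steps to methylamino that are at least modest and beyond the scatter. The third step, a step that the two limits leave unreadable from compound 1 to compound 2, cannot be sized and offers no guidance.

Compound 4 keeps the nitrogen, so the nearest guide is compound 3 at 27.2 uM in this assay. The expected outcome is a 1.1-fold higher number from compound 3 to compound 4 (0.04 log units; within the scatter), with no step beyond the scatter in either direction. Compound 4 is estimated at 30 uM, with an expected range from 10 uM to 90 uM.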

Compound 4, half-maximal toxic concentration: > 100 uM
Compound 4: no number, only a limit; the forecaster's own chance of this, stated with the estimate: 15%; at least 3.3-fold (0.52 log units) between middle value and limit.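

The single added methyl gives an at least 3.6-fold higher number from compound 3 to compound 4 (0.56 log units; beyond the scatter) in this assay, so keeping a nitrogen at this place on the shared core is not enough to give a measurable toxic concentration. Among these four compounds, a number appears only with methylamino, the one group shown with a hydrogen on that nitrogen, and dimethylamino goes against any reading that the nitrogen alone decides the outcome. Compound 4 now stands with compound 1 and compound 2 as a limit of the assay rather than a number, so its steps from those two compounds cannot be read, and the three cannot be ranked against one another: the limit of > 100 uM in this assay, at which 3 of the 4 values shown sit.

On these data alone, how far the tolerated concentration of these three compounds lies beyond that limit stays open, and so does the size of the true step from methylamino to dimethylamino. The plain amine, ethylamino or an acetamide at the same place would show whether the number in compound 3 depends on a single small group on a nitrogen that still carries a hydrogen, or is particular to methylamino.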